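Sulfonylurea thromboxane antagonists: bromophenoxy core, tert-butyl step

A few compounds are considered here, and "the series" means these few. Any claim that something is new, unique, unknown or untested is made for them only; others in the source may bear on it.

Compound 1 `Cc1cccc(Oc2ccc(C#N)cc2S(=O)(=O)NC(=O)NC(C)C)c1` is the reference point of the set. In a functional assay on HEK293 cells for antagonist activity at thromboxane A2 receptor (Homo sapiens), read by fluorescence and calcium flux (a lower number here means a stronger inhibitor, a higher number a weaker inhibitor), compound 1 gives 2380 nM. Compound 2 `Cc1cccc(Oc2ccc(C#N)cc2S(=O)(=O)NC(=O)NC(C)(C)C)c1` differs from it by methyl in place of hydrogen on a saturated chain carbon bound to an amide-type nitrogen and two saturated chain carbons; in this assay compound 2 gives 1050 nM, a step of a 2.3-fold lower number from compound 1 to compound 2 (0.36 log units; beyond the scatter). Compound 3 `CC(C)NC(=O)NS(=O)(=O)c1cc(C#N)ccc1Oc1ccc(Br)cc1` carries a different core, the difference being (4-bromophenyl in place of 3-methylphenyl on an oxygen on an aromatic ring). In this assay compound 3 gives 9470 nM, which is a 4.0-fold higher number from compound 1 to compound 3 (0.60 log units; beyond the scatter) and stands as the highest of the three numbers. Among the measured compounds shown here, compound 4 `CC(C)(C)NC(=O)NS(=O)(=O)c1cc(C#N)ccc1Oc1ccc(Br)cc1` is not yet measured; it differs from compound 3 by methyl in place of hydrogen on a saturated chain carbon bound to an amide-type nitrogen and two saturated chain carbons, the same change as the one between compound 1 and compound 2, at a place described in the same words. The change occurs twice in all among these compounds. For the measured compounds named here, the expectation for compound 4 in this assay is a step of a 2.3-fold lower number from compound 3 to compound 4 (0.36 log units; beyond the scatter), resting on the single measured precedent a 2.3-fold lower number from compound 1 to compound 2 (0.36 log units; beyond the scatter); whether the change carries over unchanged from one core to the other is untested here, so the range is kept wide. Compound 4 is expected at 4100 nM, within 1900 nM and 9000 nM.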

Compound 4, half-maximal inhibitory concentration: 5880 nM
The estimate for compound 4 lay 1.4-fold (0.16 log units) below the measured number; measured number inside the range.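

In this assay, the isopropyl to tert-butyl change on the core of compound 3 gives a 1.6-fold lower number from compound 3 to compound 4 (0.21 log units; within the scatter), and this step does not differ from its earlier counterpart: the same change on two cores in this assay, a 2.3-fold lower number (0.36 log units; beyond the scatter) from compound 1 to compound 2 and a 1.6-fold lower number (0.21 log units; within the scatter) from compound 3 to compound 4, 1.4-fold (0.15 log units) apart, within the scatter of two such steps. The 4-bromophenyl in place of 3-methylphenyl change, read with tert-butyl in place of isopropyl, gives a 5.6-fold higher number from compound 2 to compound 4 (0.75 log units; beyond the scatter), and it also agrees with its earlier counterpart: the same change on two cores in this assay, a 4.0-fold higher number (0.60 log units; beyond the scatter) from compound 1 to compound 3 and a 5.6-fold higher number (0.75 log units; beyond the scatter) from compound 2 to compound 4, 1.4-fold (0.15 log units) apart, within the scatter of two such steps. Both changes therefore carry over between these cores, but each comparison rests on a single pair of steps in one assay, and the tert-butyl step on the core of compound 3 does not by itself clear the scatter, so a lower number on that core is not shown.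

Open, from the compounds shown here alone, is whether this agreement extends to other groups in place of tert-butyl, such as cyclohexyl or a longer chain. Also open, going by these compounds, is whether it holds on a core with a carboxylic acid in place of the nitrile.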